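Propyl to butyl on the chain of compound 1

The compounds below may be only part of what the source reports. "The series", "measured", "known", "first", "only" and "open" are said of these compounds alone.

compound 1 `CCCN1CCN(c2ccc(S(=O)(=O)Oc3ccccc3OC)cc2)C1=O` gives 13000 nM
compound 2 `CCCN1CCN(c2ccc(S(=O)(=O)Oc3ccc(C)cc3)cc2)C1=O` gives 64000 nM

Within the data shown here, in a functional assay on MCF7 cells (Homo sapiens) for antiproliferative activity, read by sulforhodamine B assay, with a stated time of 48 h (a lower number here means a stronger inhibitor, a higher number a weaker inhibitor), compound 1 gives 13000 nM and holds the lower of the two numbers so far. The change to compound 3 `CCCCN1CCN(c2ccc(S(=O)(=O)Oc3ccccc3OC)cc2)C1=O` is methyl in place of hydrogen on a saturated chain carbon, three bonds along the chain from an amide-type nitrogen in a ring and reads propyl to butyl. Among the measured compounds shown here, the only measured step of a 4.9-fold higher number from compound 1 to compound 2 (0.69 log units; beyond the scatter) concerns 4-methylphenyl in place of 2-methoxyphenyl on an oxygen, not this chain, so it sets no size here. No step beyond the scatter is therefore expected, and no direction is favoured. The expected step is a 1.1-fold lower number from compound 1 to compound 3 (0.03 log units; within the scatter) on this estimate. For compound 3 the estimated value is 12000 nM with an expected range of 5000 nM to 30000 nM in this assay.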

Compound 3, half-maximal inhibitory concentration: 3800 nM
The estimate for compound 3 lay 3.2-fold (0.50 log units) above the measured number; the whole stated range lies above it.
By their numbers in this assay, from the lowest: compound 3; then compound 1; then compound 2.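

In this assay the step of a 3.4-fold lower number from compound 1 to compound 3 (0.53 log units; beyond the scatter) shows that this chain position responds to a single added methyl, which the earlier step on the oxygen substituent could not show. Propyl to butyl is therefore a change that moves the number here, and butyl is the better of the two chains on the core of compound 1. Nothing available explains this step.

From the compounds shown here alone, whether a longer chain such as pentyl lowers the number further remains open, as does the effect of a chain carrying an amine. Also open, going by these compounds, is whether butyl gives a similar step when 4-methylphenyl replaces 2-methoxyphenyl on the oxygen.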